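The source may hold more compounds than are shown below. What is called first, only, known or untested is meant among the compounds shown, and "the series" means these compounds.

Compound 1, `Cc1ncccc1C(=O)NCCC1CCN(S(=O)(=O)NC(=O)NC2CCCCC2)CC1`: 16%
Compound 2, `Cc1ncccc1C(=O)NCCC1CCN(S(=O)(=O)NC(=O)NC[C@@H]2C[C@@H]3C=C[C@@H]2C3)CC1`: 16%

In a functional assay on the whole organism (blood) with Rattus norvegicus as the target, with stated times of 24 h and 1 h, at a dose of 5 mg/kg by the intraperitoneal route (on this read-out higher numbers stand for a stronger effect at the one dose given and lower numbers for a weaker effect), compound 1 gives 16% and compound 2 gives 16%. Going by the values given here, the one measured step, no change at the digits printed from compound 1 to compound 2 (within the scatter), is within the usual scatter, so compound 2 stands level with compound 1 on this read-out and neither can be called the stronger.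

Compound 3, `O=C(NC[C@@H]1C[C@@H]2C=C[C@@H]1C2)NS(=O)(=O)N1CCC(CCNC(=O)c2nc3ccccc3s2)CC1`, differs from compound 2 in a single place: 1,3-benzothiazol-2-yl in place of 2-methylpyridin-3-yl on a carbonyl carbon. Among the compounds with values here, no measured step touches this part of the shared core; the step from compound 1 to compound 2 concerns a different group on an amide-type nitrogen and so gives no guide to the size or direction of this change. With nothing measured to point either way, the expectation for compound 3 rests on compound 2 alone, and the expected step of no change at the digits printed from compound 2 to compound 3 (within the scatter) is no change beyond the scatter. Compound 3 is therefore estimated at 16% in this assay, within a range from 3% to 38%.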

Compound 3, a percentage reported as activity, at one dose (the size of the read-out at that dose, not a potency): 24%
Estimate against measurement, compound 3: 8 percentage points below; the measured number falls inside the stated range.
By their numbers in this assay, from the lowest: compounds 1, 2 and 3 (each within the scatter of the next).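

In this assay, going by these compounds alone, the swap on the carbonyl carbon gives a number 8 percentage points higher from compound 2 to compound 3 (within the scatter) and is the first measured change at this position. The read-out therefore stays within the usual scatter when 2-methylpyridin-3-yl, with its single six-membered aromatic ring, gives way to 1,3-benzothiazol-2-yl, which has a five-membered and a six-membered aromatic ring. Nothing measured here gives a reason for this result.

Still open, as far as these compounds go, is whether a group of a different kind on this carbonyl carbon, such as a phenyl ring bearing an amine or a carboxylic acid, would move the read-out beyond the scatter. From the compounds shown here alone, it is also open whether 1,3-benzothiazol-2-yl would read the same way on the otherwise unchanged structure of compound 1.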